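The source may hold more compounds than are shown below. What is called first, only, known or untested is meant among the compounds shown, and "the series" means these compounds.

In an in vitro assay on BTI-TN-5B1-4 cells for inhibition of Amine oxidase [flavin-containing] B (Homo sapiens), read by fluorescence (a lower number here means a stronger inhibitor, a higher number a weaker inhibitor), three compounds sharing one core have been measured. Compound 1 `O=C(NC1CCCCC1)c1cc2ccccc2oc1=O` gives 500 nM. Compound 2 `O=C(Nc1ccccc1)c1cc2ccccc2oc1=O` gives 760 nM, and compound 3 `O=C(Nc1ccccc1Cc1ccccc1)c1cc2ccccc2oc1=O` gives 910 nM. Compound 2 holds the second highest of the three numbers, and both its neighbours lie within the scatter of it: the steps of a 1.5-fold higher number from compound 1 to compound 2 (0.18 log units; within the scatter) and a 1.2-fold higher number from compound 2 to compound 3 (0.08 log units; within the scatter) are each inside the usual spread. Compound 4 `CCc1ccc(NC(=O)c2cc3ccccc3oc2=O)cc1` differs from compound 2 by ethyl in place of hydrogen on an aromatic carbon. Among the measured compounds shown here, no measured step touches this position; the two known steps changed the group on the amide-type nitrogen and left the numbers essentially unmoved in this assay, so the expected step is a 1.1-fold lower number from compound 2 to compound 4 (0.04 log units; within the scatter), within the scatter. Compound 4 is therefore estimated at 700 nM in this assay, with a range from 300 nM to 1600 nM.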

Compound 4, half-maximal inhibitory concentration: 890 nM
Compound 4: the middle estimate sits 1.3-fold (0.10 log units) below what was measured; the range from low to high includes it.
By their numbers in this assay, from the lowest: compounds 1, 2, 4 and 3 (each within the scatter of the next).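

In this assay, ethyl on an aromatic carbon, para to a large group, is the first change shown at this place on the ring, and a 1.2-fold higher number from compound 2 to compound 4 (0.07 log units; within the scatter) stays inside the usual spread. This place therefore takes an ethyl, with its 2 heavy atoms and no ring, without a change in the number that can be read beyond the scatter. Going by these compounds, whether an amine, a carboxylic acid or a longer chain at the same place would give a step beyond the scatter remains open. Nothing given here offers a reason for this result.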